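The source may hold more compounds than are shown below. What is called first, only, known or untested is meant among the compounds shown, and "the series" means these compounds.

Working notes on the series, values in an ADME assay on Caco-2 cells (Homo sapiens) for permeability, in the apical to basolateral direction (a higher number here means that the compound crosses the layer faster, a lower number that the compound crosses the layer more slowly), so far:
compound 1 `CC(C)NC(=O)N1CCC(CN(C2Cc3cc(C#N)ccc3N(Cc3cncn3C)C2)S(=O)(=O)c2ccccn2)CC1` gives 0.6 10^-6 cm/s 
compound 2 `Cn1cnc(S(=O)(=O)N(Cc2cccc(-n3cccc3)c2)C2Cc3cc(C#N)ccc3N(Cc3cncn3C)C2)c1` gives 0.2 10^-6 cm/s 

Compound 2 at 0.2 10^-6 cm/s is the lower of the two, and its gap to compound 1 lies beyond the usual scatter. Still unmeasured is compound 3 `Cn1cnc(S(=O)(=O)N(CCn2cccc2)C2Cc3cc(C#N)ccc3N(Cc3cncn3C)C2)c1` with the change (1H-pyrrol-1-yl)methyl in place of 3-(1H-pyrrol-1-yl)phenyl on a saturated chain carbon bound to a sulfonamide nitrogen on a saturated chain carbon bound to a sulfonamide nitrogen. Read one bond further out, 3-(1H-pyrrol-1-yl)benzyl gives way to 2-(1H-pyrrol-1-yl)ethyl. Within the data shown here, no measured pair differs in one place only, so this exchange has no direct precedent. Among the measured compounds shown here, with compound 2 at 0.2 10^-6 cm/s the lowest number so far and compound 1 at 0.6 10^-6 cm/s the only other reference, a modest rise in this assay is expected rather than a further fall, of a size near the edge of the scatter. The expected change is a 2.0-fold higher number from compound 2 to compound 3 (0.30 log units; within the scatter) as an estimate only. For compound 3 the estimated value is 0.4 10^-6 cm/s with an expected range from 0.15 10^-6 cm/s to 1 10^-6 cm/s on repeated measurement.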

Compound 3, apparent permeability: 0.3 10^-6 cm/s
Compound 3: middle estimate off by 1.3-fold (0.12 log units), on the high side; low and high end bracket the measured number.
By their numbers in this assay, from the lowest: compounds 2, 3 and 1 (each within the scatter of the next, the first and the last beyond it).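

In this assay, among these compounds, the exchange of 3-(1H-pyrrol-1-yl)phenyl for (1H-pyrrol-1-yl)methyl on a saturated chain carbon bound to a sulfonamide nitrogen gives a 1.5-fold higher number from compound 2 to compound 3 (0.18 log units; within the scatter) and provides the first comparison of compounds differing in one place only. At this position, the 1H-pyrrol-1-yl ring stays while the six-membered aromatic ring of carbon only is lost and the group falls from 11 heavy atoms to 6, yet this single exchange does not separate the two compounds beyond the scatter. No independent measurement bears on this result, and the step itself carries no explanation.

As far as these compounds go, the role of the 1H-pyrrol-1-yl ring remains open, as compound 2 and compound 3 both carry it, and a primary amine or a carboxylic acid in its place on the same chain would test this position with a different end group. A longer chain between the sulfonamide nitrogen and the ring also remains to be compared, and only such further one-place pairs could show whether this position can move the number beyond the scatter at all.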